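Benzylthio aryl variation in the HeLa cytotoxicity series

A few compounds are considered here, and "the series" means these few. Any claim that something is new, unique, unknown or untested is made for them only; others in the source may bear on it.

Among the compounds with values here, compound 2 `Cc1cc(-c2ccccc2)n(/C(N)=N/S(=O)(=O)c2cc(C)c(Cl)cc2SCc2ccc(C(F)(F)F)cc2)n1` gives 19000 nM in a functional assay on HeLa cells (Homo sapiens) for cytotoxicity, read by MTT assay, with a stated time of 72 h (on this read-out lower numbers stand for stronger inhibition and higher numbers for weaker inhibition), the lowest of the two numbers so far; its nearest neighbour is compound 1 `Cc1cc(-c2ccccc2)n(/C(N)=N/S(=O)(=O)c2cc(C)c(Cl)cc2SCc2ccccc2C(F)(F)F)n1`, which gives 215000 nM. Compound 3 `Cc1cc(-c2ccccc2)n(/C(N)=N/S(=O)(=O)c2cc(C)c(Cl)cc2SCc2cccc3ccccc23)n1` differs from compound 2 by naphthalen-1-yl in place of 4-(trifluoromethyl)phenyl on a saturated chain carbon bound to a sulfur. Within the data shown here, the only step bearing on this site is an 11-fold lower number from compound 1 to compound 2 (1.05 log units; beyond the scatter), which shows that the aryl on this carbon moves the number strongly, but it gives no direction for a naphthalen-1-yl. A step of uncertain sign is therefore expected, a 2.4-fold higher number from compound 2 to compound 3 (0.37 log units; beyond the scatter), and compound 3 is estimated at 45000 nM, within 10000 nM to 200000 nM.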

Compound 3, half-maximal inhibitory concentration: 3000 nM
For compound 3 the middle estimate is 15-fold (1.18 log units) above the measured one; the whole stated range lies above it.
By their numbers in this assay, from the lowest: compound 3; then compound 2; then compound 1.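

In this assay, naphthalen-1-yl on this saturated chain carbon bound to a sulfur gives the lowest number of the three, with a 6.3-fold lower number from compound 2 to compound 3 (0.80 log units; beyond the scatter) and a 72-fold lower number from compound 1 to compound 3 (1.86 log units; beyond the scatter). A trifluoromethyl group is therefore not required for a low number here, and an aryl of two six-membered aromatic rings of carbon only goes lower than either trifluoromethyl-bearing phenyl. No measurement available accounts for this gain. Still open, as far as these compounds go, is how naphthalen-2-yl or an unsubstituted phenyl would compare at this carbon. Also open, from the compounds shown here alone, is what a longer chain between the sulfur and the aryl would do.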